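The source may hold more compounds than are shown below. What is called first, only, known or untested is meant among the compounds shown, and "the series" means these compounds.

Working notes on the series. Compound 1 `Cc1ccc(S(=O)(=O)NCCCNc2nccc(-c3c(-c4cccc(F)c4)nc4sccn34)n2)cc1` gives 8380 nM in a functional assay on A-375 cells (Homo sapiens) for cytotoxicity, read by MTT assay; a higher number here means a weaker inhibitor, a lower number a stronger inhibitor; this is the highest of the two numbers in hand, and its nearest neighbour is compound 2 `O=S(=O)(NCCCNc1nccc(-c2c(-c3cccc(F)c3)nc3sccn23)n1)c1ccccc1`, which in this assay gives 6600 nM, the step being a 1.3-fold lower number from compound 1 to compound 2 (0.10 log units; within the scatter). That step, hydrogen in place of methyl on an aromatic carbon, is the only measured one, and it moved nothing beyond the scatter.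

Compound 3 `O=C(NCCNc1nccc(-c2c(-c3cccc(F)c3)nc3sccn23)n1)c1ccc(Cl)cc1` has not yet been measured. It differs from compound 1 by ((4-chlorophenyl)carbonyl)amino in place of (((4-methylphenyl)sulfonyl)amino)methyl on a saturated chain carbon, two bonds along the chain from a nitrogen on an aromatic ring. The step from compound 1 to compound 2 bears on this only in part, since it too altered the group on an aromatic carbon, and it stayed within the scatter. Among the compounds with values here, no measured step speaks to the change from sulfonyl to carbonyl, nor to the shortened chain, so those parts of the change are open. The expectation is therefore for at most a modest step, a 1.4-fold lower number from compound 1 to compound 3 (0.15 log units; within the scatter), with no firm direction. Compound 3 is estimated at 6000 nM, with a range from 1500 nM to 25000 nM.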

Compound 3, half-maximal inhibitory concentration: 2570 nM
Compound 3: middle estimate off by 2.3-fold (0.37 log units), on the high side; the measured number falls inside the stated range.
By their numbers in this assay, from the lowest: compound 3; then compounds 2 and 1 (each within the scatter of the next).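

In this assay, the group on the saturated chain carbon, two bonds along the chain from a nitrogen on an aromatic ring, proves to be a place where the number moves beyond the scatter: replacing the sulfonyl-bearing group with ((4-chlorophenyl)carbonyl)amino gives a 3.3-fold lower number from compound 1 to compound 3 (0.51 log units; beyond the scatter) and a 2.6-fold lower number from compound 2 to compound 3 (0.41 log units; beyond the scatter), whereas the change on the aromatic carbon gave only a 1.3-fold lower number from compound 1 to compound 2 (0.10 log units; within the scatter). The two steps run the same way whether the leaving group is (((4-methylphenyl)sulfonyl)amino)methyl or ((phenylsulfonyl)amino)methyl, so for these three compounds the methyl on the aromatic ring does not alter the reading. No measurement here accounts for the gain in this assay.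

The change is a single replacement that combines the loss of the sulfonyl, the shorter chain and the chlorine, so the compounds shown do not assign the step to any one of these parts. Still open, from the compounds shown here alone, are the ((4-chlorophenyl)carbonyl)amino group on a longer chain, an unsubstituted benzoyl amide on the same chain as compound 3, and a simple amine or carboxylic acid at this position.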